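Swapping the Aryl Group on the Triazole: Compound 4

The source may hold more compounds than are shown below. What is called first, only, known or untested is meant among the compounds shown, and "the series" means these compounds.

Measured compounds:
compound 1 `COc1nc2ccc(Br)cc2cc1C(c1ccccc1)n1cc(-c2ccc(Br)cc2)nn1` — 10.4%
compound 2 `COc1nc2ccc(Br)cc2cc1C(c1ccccc1)n1cc(-c2cccc(F)c2)nn1` — 15.5%
compound 3 `CCCCCCCCc1cn(C(c2ccccc2)c2cc3cc(Br)ccc3nc2OC)nn1` — 12.1%

These three share one core and differ only in the group attached to the five-membered aromatic ring with three nitrogens. In an ADME assay on PANC-1 cells (Homo sapiens) for cytotoxicity, read by sulforhodamine B assay, with a stated time of 48 h, tested at 10 uM (on this read-out higher numbers stand for more inhibition at the one concentration tested (going by the name of the read-out) and lower numbers for less inhibition), compound 2 stands together with its two companions within the usual scatter: the steps of a number 5.1 percentage points higher from compound 1 to compound 2 (within the scatter) and a number 3.4 percentage points lower from compound 2 to compound 3 (within the scatter) are both too small to count as real differences.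

Compound 4 `COc1nc2ccc(Br)cc2cc1C(c1ccccc1)n1cc(-c2ccccc2C(F)(F)F)nn1` is not yet measured. It differs from compound 2 by 2-(trifluoromethyl)phenyl in place of 3-fluorophenyl on an aromatic carbon.

Within the data shown here, the steps that bear on this change are the two that also swap the group at this same carbon, from compound 1 to compound 2 and from compound 2 to compound 3. Both stayed within the scatter, and the step from compound 1 to compound 3, a number 1.7 percentage points higher from compound 1 to compound 3 (within the scatter), did as well. A 2-(trifluoromethyl)phenyl group has not been tested here, so nothing more can be drawn from the data. For compound 4 the expected value in this assay is 14%, with a range from 4% to 26%. This means an expected step of a number 1.5 percentage points lower from compound 2 to compound 4 (within the scatter), which is expected to stay within the scatter.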

Compound 4, a percentage reported as inhibition, at one concentration (the size of the read-out at that concentration, not a potency): 11.4%
The estimate for compound 4 lay 2.6 percentage points above the measured number; the measured number falls inside the stated range.
By their numbers in this assay, from the lowest: compounds 1, 4, 3 and 2 (each within the scatter of the next).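

In this assay this carbon of the five-membered ring now carries a further aromatic group, 2-(trifluoromethyl)phenyl, and the change gives a number 4.1 percentage points lower from compound 2 to compound 4 (within the scatter). The comparisons with the other two groups read the same way, with a number 0.7 percentage points lower from compound 3 to compound 4 (within the scatter) and a number 1 percentage points higher from compound 1 to compound 4 (within the scatter), so a group with three fluorine atoms and 10 heavy atoms in place of 7 still leaves all four compounds within the scatter of one another. Nothing in the data available gives a reason for this flat picture.

The compounds shown leave open whether any group at this carbon can move the read-out beyond the scatter. An amine or a carboxylic acid at the end of a carbon chain would be a different kind of group to try here.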